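Cytotoxicity of a urea analogue in the hexafluoroisopropanol series

The source may report more compounds than this note shows. Statements on the series, on what has been measured and on what is new or still open speak of the compounds shown alone.

Of the compounds shown here, three sharing one core have been tested in an ADME assay on Li23 cells (Homo sapiens) for cytotoxicity, read by WST assay; on this read-out lower numbers stand for higher toxicity in this test and higher numbers for lower toxicity in this test. Compound 1 `CN(C(=O)c1ccccc1)c1ccc(C(O)(C(F)(F)F)C(F)(F)F)cc1` gives 65000 nM. Compound 2 `Cc1cccc(C(=O)N(C)c2ccc(C(O)(C(F)(F)F)C(F)(F)F)cc2)c1` gives 20000 nM, and compound 3 `CN(C(=O)C1CCCCC1)c1ccc(C(O)(C(F)(F)F)C(F)(F)F)cc1` gives 20000 nM. On these numbers compound 3 stands level with compound 2, the two together giving the lowest numbers of the three, while compound 1 lies furthest away, as a 3.3-fold lower number from compound 1 to compound 3 (0.51 log units; beyond the scatter) shows. The step from compound 2 to compound 3, exchanging the 3-methylphenyl for a cyclohexyl on the carbonyl carbon, is no change at the digits printed from compound 2 to compound 3 (within the scatter).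

Compound 4 `CN(C(=O)Nc1ccccc1)c1ccc(C(O)(C(F)(F)F)C(F)(F)F)cc1` differs from compound 3 by anilino in place of cyclohexyl on a carbonyl carbon. The step that bears most on this change is the one from phenyl to cyclohexyl on the same carbonyl carbon, a 3.3-fold lower number from compound 1 to compound 3 (0.51 log units; beyond the scatter), which carried an aromatic ring out of that position; compound 4 brings an aromatic ring back in, now with a hydrogen-bond donor between it and the carbonyl. For the measured compounds named here, no measured pair shows the effect of that donor, so the expectation rests on the return of the aromatic ring alone. Compound 4 is therefore expected to move back toward compound 1 by a 1.8-fold higher number from compound 3 to compound 4 (0.24 log units; within the scatter), a modest rise. The estimate for compound 4 in this assay is 35000 nM, with a range from 12000 nM to 100000 nM.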

Compound 4, half-maximal cytotoxic concentration: > 20000 nM
Compound 4 ended at the assay's limit (the forecaster's own chance of this, stated with the estimate: 20%); the middle value lies beyond the limit too.
By their numbers in this assay, from the lowest: compounds 2 and 3 (each within the scatter of the next); then compound 1.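

In this assay compound 4 gives > 20000 nM, which is a limit of the assay and not a number: the limit of > 20000 nM in this assay, at which 1 of the 4 values shown sits. Even so, the anilino group on this carbonyl carbon gives a number no lower from compound 3 to compound 4 (the limit leaves the size open) and a number no lower from compound 2 to compound 4 (the limit leaves the size open), so the first group shown here that brings a nitrogen and a hydrogen-bond donor to this position does not take the number under those of the cyclohexyl and 3-methylphenyl compounds, whereas the earlier steps from compound 1 showed only falls. Going by these compounds, the size of these two steps stays unknown, and the comparison of compound 4 with compound 1 cannot be read at all, so whether anilino sits level with phenyl, under it or over it cannot be said.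

The compounds shown leave open whether the nitrogen with its hydrogen or the aromatic ring of the anilino group governs this read-out, since both enter together in the one change. A cyclohexylamino group or a methylanilino group on the same carbonyl carbon would pull these two features apart, and a benzylamino group would show what a longer link to the aromatic ring does.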